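The source may report more compounds than this note shows. Statements on the series, on what has been measured and on what is new or still open speak of the compounds shown alone.

Compound 1 (`COC(=O)c1scc(-c2ccc(NC(=O)c3cccc(C(F)(F)F)c3)cc2)c1OC`), compound 2 (`COC(=O)c1scc(-c2ccc(NC(=O)c3ccc(C(F)(F)F)cc3Br)cc2)c1OC`) and compound 3 (`COC(=O)c1scc(-c2ccc(NC(=O)c3cccc(I)c3)cc2)c1OC`) share one core and differ in the aromatic ring on the amide carbonyl. In a functional assay on K562 cells (Homo sapiens) for antiproliferative activity, read by MTT assay, with a stated time of 24 h (on this read-out higher numbers stand for weaker inhibition and lower numbers for stronger inhibition), compound 3 gives 14700 nM. Compound 2 gives 9250 nM, which lies within the usual scatter of compound 3, so these two cannot be told apart. For the measured compounds named here, compound 1 gives 6130 nM, and only this value stands clearly apart from that of compound 3.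

The next molecule is compound 4 (`COC(=O)c1scc(-c2ccc(NC(=O)c3ccc(C(F)(F)F)cc3)cc2)c1OC`), which has not yet been measured. The change is 4-(trifluoromethyl)phenyl in place of 3-iodophenyl on a carbonyl carbon; in words, 4-(trifluoromethyl)phenyl in place of 3-iodophenyl on a carbonyl carbon.

Going by the values given here, one measured step bears on this: iodo in place of trifluoromethyl gave a 2.4-fold higher number from compound 1 to compound 3 (0.38 log units; beyond the scatter). Read backwards, it suggests that trifluoromethyl in place of iodo could lower the number. It is only a partial guide, since the ring of compound 4 is not the ring of compound 1. Compound 2 also carries trifluoromethyl, yet it stays within the scatter of compound 3, and so goes against any simple rule. A modest step towards a lower number is therefore expected in this assay, though it may not clear the scatter.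

The expected change is a 2.1-fold lower number from compound 3 to compound 4 (0.32 log units; beyond the scatter).

For compound 4 the estimated value is 7000 nM, with an expected range from 3000 nM to 16000 nM.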

Compound 4, half-maximal inhibitory concentration: 9260 nM
Compound 4: the middle estimate sits 1.3-fold (0.12 log units) below what was measured; low and high end bracket the measured number.
By their numbers in this assay, from the lowest: compounds 1, 2, 4 and 3 (each within the scatter of the next, the first and the last beyond it).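

In this assay the swap of 3-iodophenyl for 4-(trifluoromethyl)phenyl on the carbonyl carbon (a 1.6-fold lower number from compound 3 to compound 4 (0.20 log units; within the scatter)) stays within the scatter, so the clear gap seen earlier between trifluoromethyl and iodo holds only for compound 1 and compound 3 and does not extend to this new ring. Two further single changes also leave the number unresolved: hydrogen in place of bromo (a 1.0-fold higher number from compound 2 to compound 4 (0.00 log units; within the scatter)) and 4-(trifluoromethyl)phenyl in place of 3-(trifluoromethyl)phenyl (a 1.5-fold higher number from compound 1 to compound 4 (0.18 log units; within the scatter)), so neither the bromo group nor the place of the trifluoromethyl group makes a readable difference in this assay. No measurement at hand accounts for how closely these compounds sit together.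

The rings shown carry only trifluoromethyl, bromo or iodo, so it remains open whether an amine or a carboxylic acid on the ring would move the number clearly beyond the scatter. A 4-iodophenyl group on the same carbonyl carbon would also show whether iodo and trifluoromethyl can be told apart when both have the same place on the ring.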